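Notes on compound 3 and compound 4

This account rests on a few compounds, and the source may have more. Where it says the series, first, only, none or still open, it means among the compounds named here.

Compound 1 `CC(C)c1cccc(C(C)C)c1NC(=O)CC(=O)O` reaches only a limit of > 5000 nM in an assay on microsomes from intestine for inhibition of acyl-CoA:cholesterol acyltransferase (Oryctolagus cuniculus); a lower number here means a stronger inhibitor, a higher number a weaker inhibitor. Compound 2 `CC(C)c1cccc(C(C)C)c1OC(=O)CC(=O)Nc1c(F)cc(F)cc1F` likewise gives only the limit of > 5000 nM in this assay. Within the data shown here, compound 3 `CCCCCCCCCCOC(=O)CC(=O)Nc1c(C(C)C)cccc1C(C)C` gives 53 nM in this assay, the only real number among the three values shown; the other two sit at the limit of > 5000 nM in this assay, at which 2 of the 3 values shown sit. Among the measured compounds shown here, no pair of measured compounds differs in one place, so no measured step can be counted, and the three values say nothing about how any single group acts.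

Compound 4 `CCCCCCOC(=O)CC(=O)Nc1c(C(C)C)cccc1C(C)C` is still to be measured in this assay. It differs from compound 3 by hydrogen in place of butyl on a saturated chain carbon, six bonds along the chain from an oxygen next to a carbonyl group, a shortening of the chain six bonds along from an oxygen next to a carbonyl group. Nothing measured here shows how chain length moves the number. The expected step is a 2.8-fold higher number from compound 3 to compound 4 (0.45 log units; beyond the scatter), a modest loss that may lie beyond the scatter. Compound 4 is estimated at 150 nM, with a range from 50 nM to 600 nM.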

Compound 4, half-maximal inhibitory concentration: 810 nM
The estimate for compound 4 lay 5.4-fold (0.73 log units) below the measured number; measured number outside the range, above it.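

In this assay, among these compounds, the first measured step on this chain shows that its length matters at this place, six bonds along the chain from an oxygen next to a carbonyl group, where hydrogen in place of butyl gives a large loss: a 15-fold higher number from compound 3 to compound 4 (1.18 log units; beyond the scatter). Hexyl in place of hydrogen on an oxygen next to a carbonyl group also carries weight, even with the shorter chain: an at least 6.1-fold lower number from compound 1 to compound 4 (0.79 log units; beyond the scatter). The entry for compound 1 is a limit and not a number, so that second step gives only a bound: the limit of > 5000 nM in this assay, at which 2 of the 4 values shown sit.

Going by these compounds, two chain lengths fix no trend, so it remains open whether a longer chain would go beyond compound 3 or how the number falls between the two lengths. Also open, on these data alone, is how an amine or a carboxylic acid carried on the chain would act.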